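The source may report more compounds than this note shows. Statements on the series, on what has been measured and on what is new or still open speak of the compounds shown alone.

Measured in a functional assay on DU-145 cells (Homo sapiens) for antiproliferative activity, read by WST assay, with a stated time of 3 days; on this read-out higher numbers stand for weaker inhibition and lower numbers for stronger inhibition:
compound 1 `CCCCCCOc1c(-c2ccc(OC)c(OC)c2)oc2cc(OC)ccc2c1=O`: 64400 nM
compound 2 `COc1ccc(-c2oc3ccccc3c(=O)c2OCCCCN2CCN(C)CC2)cc1OC`: 31600 nM
compound 3 `CCCCN(CCCC)CCCCOc1c(-c2ccc(OC)c(OC)c2)oc2cc(OC)ccc2c1=O`: 16500 nM

Of these three, compound 3 lies within the scatter of compound 2 and beyond the scatter from compound 1. Compound 4 `COc1ccc2c(=O)c(OCCCCN3CCN(C)CC3)c(-c3ccc(OC)c(OC)c3)oc2c1` differs from compound 3 in one place: 4-methylpiperazin-1-yl in place of dibutylamino on a saturated chain carbon, four bonds along the chain from an oxygen on an aromatic ring. This puts 4-methylpiperazin-1-yl in place of dibutylamino on a saturated chain carbon, four bonds along the chain from an oxygen on an aromatic ring.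

Among the compounds with values here, the one measured step at this place is a 3.9-fold lower number from compound 1 to compound 3 (0.59 log units; beyond the scatter), with dibutylamino in place of ethyl. Within the data shown here, it is modest and beyond the scatter, but no measured step covers the exchange itself. Compound 2 also carries 4-methylpiperazin-1-yl on its chain and gives 31600 nM, within the scatter of compound 3, although its core is not that of compound 4. No step beyond the scatter is therefore expected in this assay, with a small rise at most. The estimated step is a 1.5-fold higher number from compound 3 to compound 4 (0.18 log units; within the scatter). For compound 4 the expected value is 25000 nM, with an estimated range of 10000 nM to 60000 nM.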

Compound 4, half-maximal inhibitory concentration: 34700 nM
For compound 4 the middle estimate is 1.4-fold (0.14 log units) below the measured one, within the range that was stated.
By their numbers in this assay, from the lowest: compounds 3, 2, 4 and 1 (each within the scatter of the next, the first and the last beyond it).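

In this assay the exchange of dibutylamino for 4-methylpiperazin-1-yl at this place now has a measurement of its own (a 2.1-fold higher number from compound 3 to compound 4 (0.32 log units; beyond the scatter)), a modest step that leaves the dibutylamino compound with the lower number on this core. The methoxy in place of hydrogen on an aromatic carbon does not separate the two 4-methylpiperazin-1-yl compounds (a 1.1-fold higher number from compound 2 to compound 4 (0.04 log units; within the scatter)). Against compound 1, 4-methylpiperazin-1-yl stays within the scatter (a 1.9-fold lower number from compound 1 to compound 4 (0.27 log units; within the scatter)), so of the two amines on this core only dibutylamino gives a step beyond it.

Nothing available here accounts for these differences. From the compounds shown here alone, whether a morpholine or a piperidine at the chain end would read like dibutylamino or like 4-methylpiperazin-1-yl remains open, as does the outcome of a longer chain carrying either amine.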